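Compound 3 to compound 4: ethyl becomes isopropyl

This account rests on a few compounds, and the source may have more. Where it says the series, first, only, none or still open, it means among the compounds named here.

Measured in a functional assay on MCF7 cells (Homo sapiens) for antiproliferative activity; a lower number here means a stronger inhibitor, a higher number a weaker inhibitor:
- Compound 1 `CC(C)=CCc1cc(C(=O)Nc2cc3ccc(OCC4CCCN(C)C4)c(C)c3oc2=O)ccc1O`: 2640 nM
- Compound 2 `CC(C)=CCc1cc(C(=O)Nc2cc3ccc(OCCCN4CCCC4)c(C)c3oc2=O)ccc1O`: 990 nM
- Compound 3 `CCN(C)CCCOc1ccc2cc(NC(=O)c3ccc(O)c(CC=C(C)C)c3)c(=O)oc2c1C`: 2190 nM

Compound 4 `CC(C)=CCc1cc(C(=O)Nc2cc3ccc(OCCCN(C)C(C)C)c(C)c3oc2=O)ccc1O` has not yet been measured.

In this assay compound 3 gives 2190 nM. This places it within the scatter of compound 1, the step being a 1.2-fold lower number from compound 1 to compound 3 (0.08 log units; within the scatter). Compound 2 remains clearly apart from it, with a 2.2-fold higher number from compound 2 to compound 3 (0.34 log units; beyond the scatter).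

The change under consideration is methyl in place of hydrogen on a saturated chain carbon bound to an amine nitrogen and a saturated chain carbon. Ethyl(methyl)amino thus becomes isopropyl(methyl)amino.

Within the data shown here, no measured step makes this exact change. The closest evidence comes from replacing the whole amine group. The step of a 2.2-fold higher number from compound 2 to compound 3 (0.34 log units; beyond the scatter) is modest, as is a 2.7-fold lower number from compound 1 to compound 2 (0.43 log units; beyond the scatter), while a 1.2-fold lower number from compound 1 to compound 3 (0.08 log units; within the scatter) does not register at all. Among the measured compounds shown here, with only three values, these steps give no direction for a single added methyl, so a small step at most is expected.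

The expected step is a 1.1-fold lower number from compound 3 to compound 4 (0.04 log units; within the scatter), which would be no real change. For compound 4 the estimated value in this assay is 2000 nM, with an expected range of 1000 nM to 3900 nM.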

Compound 4, half-maximal inhibitory concentration: 1050 nM
Compound 4: the middle estimate sits 1.9-fold (0.28 log units) above what was measured; measured number inside the range.
By their numbers in this assay, from the lowest: compounds 2 and 4 (each within the scatter of the next); then compounds 3 and 1 (each within the scatter of the next).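

In this assay a single added methyl on a saturated chain carbon bound to an amine nitrogen and a saturated chain carbon, turning ethyl(methyl)amino into isopropyl(methyl)amino, gives a 2.1-fold lower number from compound 3 to compound 4 (0.32 log units; beyond the scatter) and so shows that this one position can shift the number beyond the scatter, which the earlier swaps of the whole amine group could not isolate. The open-chain isopropyl(methyl)amino group also stands level with the pyrrolidin-1-yl group, with a 1.1-fold higher number from compound 2 to compound 4 (0.03 log units; within the scatter) as the step, while a 2.5-fold lower number from compound 1 to compound 4 (0.40 log units; beyond the scatter) separates it from the 1-methylpiperidin-3-yl compound. Ring versus open chain therefore does not sort these four compounds: compound 2 with its ring and compound 4 without one share the low end of the range, while compound 1 with its ring and compound 3 without one share the high end.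

Nothing measured here accounts for the effect of the added methyl on the antiproliferative number.

As far as these compounds go, it also remains open whether the number would keep falling with a tert-butyl or cyclopentyl group in the same place on the amine nitrogen, or would rise again.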